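The source may hold more compounds than are shown below. What is called first, only, known or untested is meant among the compounds shown, and "the series" means these compounds.

In an ADME assay on microsomes (Homo sapiens) for metabolic stability (a higher number here means that the compound lasts longer, a lower number that the compound disappears faster), compound 1 (`O=C(C1CCN(C(=O)C(F)(F)F)CC1)N1N=CCC1c1ccccc1`) stands at > 1.5 h as a limit and not a number. Compound 3 (`CC(=O)N1CCC(C(=O)N2N=CC[C@H]2c2ccccc2)CC1`) reads > 2.75 h and this too is a limit. Compound 2 (`O=C(C1CCC1)N1N=CCC1c1ccccc1`) gives 1.38 h as a measured number. Compound 4 (`O=C(c1cocn1)N1CCC(C(=O)N2N=CCC2c2ccccc2)CC1`) differs from compound 1 in one place (1,3-oxazol-4-yl in place of trifluoromethyl on a carbonyl carbon): 1,3-oxazol-4-yl in place of trifluoromethyl on a carbonyl carbon. Going by the values given here, no measured pair shows this change, so no step beyond the scatter is expected in this assay and no direction is favoured. The expected step is a step that the limit leaves unreadable from compound 1 to compound 4 as an estimate only. The estimate for compound 4 is 1.8 h with an expected range from 0.8 h to 4 h as the working figure.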

Compound 4, half-life: > 2.75 h
Compound 4 was reported as a limit; the forecaster's own chance of this, stated with the estimate: 35%; at least 1.5-fold (0.18 log units) between middle value and limit.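

In this assay, going by these compounds alone, compound 1 and compound 4 are both reported as limits, so no step between them can be read. The compounds shown leave open whether 1,3-oxazol-4-yl in place of trifluoromethyl on a carbonyl carbon shifts the half-life at all, and in which direction.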